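This account rests on a few compounds, and the source may have more. Where it says the series, first, only, none or still open, it means among the compounds named here.

Working notes on the hydroxamate series

Three compounds have numbers in an assay on isolated protein for inhibition of protein deacetylase HDAC6 (Homo sapiens), read by fluorescence, with a stated time of 90 min (a lower number here means a stronger inhibitor, a higher number a weaker inhibitor), so far. Compound 1 `O=C(NO)c1coc(C(c2ccccc2)c2ccccc2)n1` carries a branched substituent on the shared core and gives 9370 nM. Compound 2 `O=C(NO)c1coc(-c2ccc3ccccc3c2)n1` carries a fused bicyclic aromatic group and gives 89 nM. Compound 3 `O=C(NO)c1noc(-c2ccccc2)n1` has a different core with a plain phenyl group and gives 112 nM. On these numbers compound 3 stands second highest of the three: its value and that of compound 2 lie within the scatter of each other, while compound 1 sits far beyond the scatter with the much higher number.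

Compound 4 `O=C(NO)c1noc(-c2ccc(Br)cc2)n1` has not been measured. It differs from compound 3 by bromo in place of hydrogen on an aromatic carbon, para to a group of 9 heavy atoms. Among the measured compounds shown here, no measured pair in the set shows this kind of change, so the size of the step can only be anticipated. Since compound 2 and compound 3 show that an added aromatic ring leaves the number near 112 nM, the expectation is a small step, if any, and toward a somewhat lower number: from compound 3 to compound 4 a step of a 1.4-fold lower number from compound 3 to compound 4 (0.15 log units; within the scatter) is expected, within or at the edge of the scatter. Compound 4 is therefore estimated at 80 nM in this assay, with a range from 30 nM to 250 nM.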

Compound 4, half-maximal inhibitory concentration: 2770 nM
Estimate against measurement, compound 4: 35-fold (1.54 log units) below, and the stated range ends below it.
By their numbers in this assay, from the lowest: compounds 2 and 3 (each within the scatter of the next); then compound 4; then compound 1.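

In this assay the change from hydrogen to bromo on an aromatic carbon, para to a group of 9 heavy atoms, gives a 25-fold higher number from compound 3 to compound 4 (1.39 log units; beyond the scatter) as the first step read between compounds differing in one place. It shows that this position on the phenyl group of compound 3 does not accept every change without consequence, as a single added heavy atom is enough for a large move toward weaker inhibition. Nothing among the data shown accounts for the size of this step.

Going by these compounds, it remains open whether the step belongs to bromo in particular or would also appear with a smaller group such as fluoro, methyl or an amine in the same place. On these data alone, the effect of bromo elsewhere on the ring also remains open.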